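This account rests on a few compounds, and the source may have more. Where it says the series, first, only, none or still open, it means among the compounds named here.

Compound 1 (`CCOc1cc(NC(=O)CCCCCC(=O)Nc2cc(-c3ccccc3)ccc2N)cc2c1OCC([N+](=O)[O-])=C2`), compound 2 (`CCOc1cc(NC(=O)CCCCC(=O)Nc2cc(-c3ccccc3)ccc2N)cc2c1OCC([N+](=O)[O-])=C2`) and compound 3 (`CCOc1cc(NC(=O)CCCCCCC(=O)Nc2cc(-c3ccccc3)ccc2N)cc2c1OCC([N+](=O)[O-])=C2`) share one core and differ only in the length of a chain. In a functional assay on MCF7 cells (Homo sapiens) for antiproliferative activity, read by MTT assay, with a stated time of 48 h (a higher number here means a weaker inhibitor of growth, a lower number a stronger inhibitor of growth), compound 1 gives 7030 nM, compound 2 gives 19900 nM and compound 3 gives 9370 nM. Compound 3 therefore stands in the middle of the three numbers. Its gap to compound 1 lies within the usual scatter of repeated measurements, while its gap to compound 2 lies beyond that scatter, with compound 2 having the higher number.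

Compound 4 (`CCOc1cc(NC(=O)CCCCCCC(=O)Nc2ccccc2N)cc2c1OCC([N+](=O)[O-])=C2`) keeps the chain of compound 3 but carries hydrogen in place of phenyl on an aromatic carbon. This change sits para to an amino group and meta to a large group. Within the data shown here, none of the measured compounds lacks this phenyl, so the data show neither the size nor the direction of such a step. With no evidence for a shift, the expectation in this assay is no change beyond the scatter. The expected step is small, a 1.2-fold higher number from compound 3 to compound 4 (0.07 log units; within the scatter). Compound 4 is estimated at 11000 nM, with an expected range from 4000 nM to 30000 nM.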

Compound 4, concentration for 50% growth inhibition: 13500 nM
Beside the measured number, compound 4's estimate is 1.2-fold (0.09 log units) below it; measured number inside the range.
By their numbers in this assay, from the lowest: compounds 1, 3, 4 and 2 (each within the scatter of the next, the first and the last beyond it).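

Among these compounds, putting hydrogen in place of phenyl on this aromatic carbon, para to an amino group and meta to a large group, gives a 1.4-fold higher number from compound 3 to compound 4 (0.16 log units; within the scatter) in this assay and is the only change here outside the chain. With the chain of compound 3, then, the whole phenyl ring can leave this position without a shift beyond the usual scatter, so the phenyl is not required for the growth inhibition that compound 3 shows in this cell assay. No measurement at hand explains why this position tolerates the change, and the two numbers alone cannot supply a reason.

On these data alone, whether hydrogen in place of phenyl would read the same with the shorter chains of compound 1 and compound 2 remains open. Among the compounds shown here, also open is how this aromatic carbon would respond to a different group, such as a methoxy group, a fluorine atom or a pyridine ring, since phenyl and hydrogen are the only two groups seen there so far.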